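Moving the Methyl Around a Cyclohexyl Amide Substituent

This account rests on a few compounds, and the source may have more. Where it says the series, first, only, none or still open, it means among the compounds named here.

Measured so far in an in vitro functional assay on cells for antagonist activity at B1 bradykinin receptor (Homo sapiens), read by luminescence and calcium flux, with a stated time of 2 h; on this read-out higher numbers stand for weaker inhibition and lower numbers for stronger inhibition:
compound 1, `Cc1ccc(S(=O)(=O)N2C=CNC(=O)[C@H]2CC(=O)N[C@H](C)c2ccccc2)cc1`, gives 836 nM
compound 2, `Cc1ccc(S(=O)(=O)N2C=CNC(=O)[C@H]2CC(=O)NC2CCNc3ccccc32)cc1`, gives 21.6 nM
compound 3, `Cc1ccc(S(=O)(=O)N2C=CNC(=O)[C@H]2CC(=O)NC2CCC(C)CC2)cc1`, gives 314 nM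

Compound 3 stands second highest of the three numbers: it sits closer to compound 1, as a 2.7-fold lower number from compound 1 to compound 3 (0.43 log units; beyond the scatter) shows, than to compound 2, which is far stronger, as a 15-fold higher number from compound 2 to compound 3 (1.16 log units; beyond the scatter) shows. Compound 4, `Cc1ccc(S(=O)(=O)N2C=CNC(=O)[C@H]2CC(=O)NC2CCCCC2C)cc1`, keeps every atom of compound 3 and differs only in how they are joined: 2-methylcyclohexyl in place of 4-methylcyclohexyl on an amide-type nitrogen.

Going by the values given here, none of the measured steps moves a methyl from one place on a saturated ring to another. The two steps that touch compound 3 exchange the whole group on the amide nitrogen for a quite different one, and both are large. They show that this position matters, but they give no direction for a shift of a methyl within the same ring. For compound 4 the step from compound 3 is therefore expected to be small, a 1.1-fold higher number from compound 3 to compound 4 (0.05 log units; within the scatter), most likely within the scatter and of uncertain direction. Compound 4 is estimated at 350 nM, with a range from 120 nM to 1000 nM.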

Compound 4, half-maximal inhibitory concentration: 25.9 nM
Beside the measured number, compound 4's estimate is 14-fold (1.13 log units) above it; measured number below the stated range.
By their numbers in this assay, from the lowest: compounds 2 and 4 (each within the scatter of the next); then compound 3; then compound 1.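

In this assay, the place of the methyl on the ring matters a great deal: with the same atoms joined differently, the change from 4-methylcyclohexyl to 2-methylcyclohexyl gives a 12-fold lower number from compound 3 to compound 4 (1.08 log units; beyond the scatter). The new group, which has no aromatic ring and no ring nitrogen, also brings compound 4 level with the two-ring group of compound 2, at a 1.2-fold higher number from compound 2 to compound 4 (0.08 log units; within the scatter), and well clear of the 1-phenylethyl amide, at a 32-fold lower number from compound 1 to compound 4 (1.51 log units; beyond the scatter). Nothing available here explains why moving one methyl has so large an effect.

Plain cyclohexyl, with no methyl at all, is absent from this set, so it remains open whether the methyl of 2-methylcyclohexyl helps or that of 4-methylcyclohexyl hurts. Also open, from the compounds shown here alone, is whether an ethyl or a hydroxyl group in place of that methyl would keep the number of compound 4.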